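Compound 4: hydroxymethyl in place of methoxy on the carbonyl

The compounds below may be only part of what the source reports. "The series", "measured", "known", "first", "only" and "open" are said of these compounds alone.

Measured in an assay on isolated protein for displacement of a labelled ligand from 5-hydroxytryptamine receptor 6 (Homo sapiens); a lower number here means a stronger inhibitor, a higher number a weaker inhibitor:
compound 1 `O=S(=O)(c1cccc(F)c1)c1ccc2c(c1)CCC[C@H]2CN1CC(O)C1` gives 0.1 nM
compound 2 `CNCC(=O)NC[C@@H]1CCCc2cc(S(=O)(=O)c3cccc(F)c3)ccc21` gives 0.159 nM
compound 3 `COC(=O)NC[C@@H]1CCCc2cc(S(=O)(=O)c3cccc(F)c3)ccc21` gives 1.59 nM

Compound 3 stands at the highest number of the three, set off by a 10-fold higher number from compound 2 to compound 3 (1.00 log units; beyond the scatter) and a 16-fold higher number from compound 1 to compound 3 (1.20 log units; beyond the scatter). Compound 4 `O=C(CO)NC[C@@H]1CCCc2cc(S(=O)(=O)c3cccc(F)c3)ccc21` is not yet measured; against compound 3 the change is hydroxymethyl in place of methoxy on a carbonyl carbon. Going by the values given here, the one step that touches this place is a 10-fold higher number from compound 2 to compound 3 (1.00 log units; beyond the scatter), which turned only on the group at the carbonyl carbon, while compound 2 with (methylamino)methyl there sits near compound 1, as a 1.6-fold higher number from compound 1 to compound 2 (0.20 log units; within the scatter) shows. A hydroxymethyl group on the same carbon is expected to move the number back toward compound 2, by a 4.0-fold lower number from compound 3 to compound 4 (0.60 log units; beyond the scatter). Compound 4 is estimated at 0.4 nM in this assay, within 0.1 nM to 1.6 nM.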

Compound 4, inhibition constant: 0.1 nM
Beside the measured number, compound 4's estimate is 4.0-fold (0.60 log units) above it, within the range that was stated.
By their numbers in this assay, from the lowest: compounds 1, 4 and 2 (each within the scatter of the next); then compound 3.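

At the carbonyl carbon, the swap of methoxy for hydroxymethyl keeps the same heavy-atom count yet gives a 16-fold lower number from compound 3 to compound 4 (1.20 log units; beyond the scatter), so the weak number of compound 3 belongs to methoxy and not to carbonyl substitution in general. The amine of compound 2 is not needed for a low number: hydroxy in place of methylamino gives a 1.6-fold lower number from compound 2 to compound 4 (0.20 log units; within the scatter), and the change from 3-hydroxyazetidin-1-yl gives no change at the digits printed from compound 1 to compound 4 (within the scatter). No measurement shown here accounts for the methoxy result.

Still open, from the compounds shown here alone, is how methoxymethyl or a longer hydroxyalkyl chain on this carbonyl carbon would read. Going by these compounds, a carboxylic acid at the end of that chain is equally open.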